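The compounds below may be only part of what the source reports. "The series", "measured", "known", "first", "only" and "open" are said of these compounds alone.

Compound 1 `COc1cc(N(C)CCN(C)C)c(NC(=O)/C=C\C(C)C)cc1Nc1nc2c(c(-c3cn(C)c4ccccc34)n1)CSCC2` and compound 2 `CCC/C=C\C(=O)Nc1cc(Nc2nc3c(c(-c4cn(C)c5ccccc45)n2)CSCC3)c(OC)cc1N(C)CCN(C)C` share one core, and in a functional assay on A549 cells (Homo sapiens) for inhibition, read by MTT assay, with a stated time of 72 h (on this read-out lower numbers stand for stronger inhibition and higher numbers for weaker inhibition), compound 1 gives 788 nM while compound 2 gives 571 nM. The change between them, (propyl in place of isopropyl on a double-bonded chain carbon bound to a double-bonded chain carbon), produced a step of a 1.4-fold lower number from compound 1 to compound 2 (0.14 log units; within the scatter), so the two values are not told apart by this measurement.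

Compound 3 `COc1cc(N(C)CCN(C)C)c(NC(=O)/C=C\C(C)C)cc1Nc1nc2c(c(-c3cn(C)c4ccc(F)cc34)n1)CS(=O)(=O)CC2` rests on a different core; how the two cores differ is not broken down here. In this assay, among the measured compounds shown here, compound 3 gives 3750 nM, the highest of the three numbers so far, and its gap to compound 1 and to compound 2 is beyond the scatter.

Compound 4 `CCC/C=C\C(=O)Nc1cc(Nc2nc3c(c(-c4cn(C)c5ccc(F)cc45)n2)CS(=O)(=O)CC3)c(OC)cc1N(C)CCN(C)C` carries the same change on the core of compound 3: propyl in place of isopropyl on a double-bonded chain carbon bound to a double-bonded chain carbon. Because the same change gave only a 1.4-fold lower number from compound 1 to compound 2 (0.14 log units; within the scatter), the expected step is small; the estimate for the move from compound 3 to compound 4 is a 1.3-fold lower number from compound 3 to compound 4 (0.11 log units; within the scatter). For the measured compounds named here, for compound 4 in this assay the expected value is 2900 nM, with a likely range from 1300 nM to 6500 nM, which rests on the single earlier pair alone.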

Compound 4, half-maximal inhibitory concentration: 7570 nM
Compound 4: the middle estimate sits 2.6-fold (0.42 log units) below what was measured; measured number above the stated range.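

On the second core, the swap of isopropyl for propyl did not repeat what it had done on the first: in this assay it gave a 2.0-fold higher number from compound 3 to compound 4 (0.31 log units; beyond the scatter). In this series, then, the size and direction of a step seen on one core cannot simply be carried to the other, and the two steps really do differ: the same change on two cores in this assay, a 1.4-fold lower number (0.14 log units; within the scatter) from compound 1 to compound 2 and a 2.0-fold higher number (0.31 log units; beyond the scatter) from compound 3 to compound 4, 2.8-fold (0.44 log units) apart, beyond the scatter of two such steps. This rests on just two pairs of compounds, so it shows that the result of this one change varies with the core, but it does not show which difference between the cores is responsible or whether other changes would carry over any better.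

As far as these compounds go, it remains open whether a butyl group, a longer chain or a chain ending in an amine, placed on the same double-bonded chain carbon, would also behave differently on the two cores. The compounds shown also leave open how each separate difference between the cores contributes, since those differences are not taken apart one at a time here.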